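Nitro in Place of Bromo: From Compound 1 to Compound 4

A few compounds are considered here, and "the series" means these few. Any claim that something is new, unique, unknown or untested is made for them only; others in the source may bear on it.

Measured compounds:
compound 1, `O=C(Nc1cccc(-c2oc3cc(-c4ccc(F)cc4)ccc3c(=O)c2O)c1)c1ccc(Br)cc1`, 24000 nM
compound 2, `Cc1cccc(C(=O)Nc2cccc(-c3oc4cc(-c5ccc(F)cc5)ccc4c(=O)c3O)c2)c1`, 7850 nM
compound 3, `COc1cc(OC)cc(C(=O)Nc2cccc(-c3oc4cc(-c5ccc(F)cc5)ccc4c(=O)c3O)c2)c1`, 3470 nM

In a functional assay on MCF7 cells (Homo sapiens) for antiproliferative activity, read by CCK-8 assay, with a stated time of 72 h (a lower number here means a stronger inhibitor, a higher number a weaker inhibitor), compound 1 stands with the highest number of the three measured compounds. Its nearest neighbour is compound 2, reached by a 3.1-fold lower number from compound 1 to compound 2 (0.49 log units; beyond the scatter), and the furthest is compound 3, reached by a 6.9-fold lower number from compound 1 to compound 3 (0.84 log units; beyond the scatter); between those two lies a 2.3-fold lower number from compound 2 to compound 3 (0.35 log units; beyond the scatter). All three steps are beyond the scatter, and all three change the same part of the molecule, the aryl group on the carbonyl carbon.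

Compound 4, `O=C(Nc1cccc(-c2oc3cc(-c4ccc(F)cc4)ccc3c(=O)c2O)c1)c1ccc([N+](=O)[O-])cc1`, changes that same part. nitro in place of bromo on an aromatic carbon Here the difference is placed on the 4-bromophenyl ring itself, para to a large group, rather than replacing the whole ring pattern as in compounds 2 and 3. Within the data shown here, no measured step touches a nitro group, so the measured steps bear on compound 4 only in showing that this position of the molecule moves the number, and that compound 1 sits at the weak end. The expected step in this assay is therefore a modest move toward a lower number, with wide uncertainty: a 1.6-fold lower number from compound 1 to compound 4 (0.20 log units; within the scatter) is the estimated step. Compound 4 is expected to give 15000 nM, within a range from 5000 nM to 45000 nM.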

Compound 4, half-maximal inhibitory concentration: 3970 nM
The estimate for compound 4 lay 3.8-fold (0.58 log units) above the measured number, and the stated range ends above it.
By their numbers in this assay, from the lowest: compounds 3, 4 and 2 (each within the scatter of the next, the first and the last beyond it); then compound 1.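

Among these compounds, with only the group on the aromatic carbon para to a large group exchanged, nitro in place of bromo gives a 6.0-fold lower number from compound 1 to compound 4 (0.78 log units; beyond the scatter) in this assay and thus shows that this single atom-level change on the ring can move the number by itself, whereas the earlier steps replaced the substitution pattern of the whole aryl group. The 4-nitrophenyl group also brings compound 4 level with the two other aryl groups, with a 1.1-fold higher number from compound 3 to compound 4 (0.06 log units; within the scatter) and a 2.0-fold lower number from compound 2 to compound 4 (0.30 log units; within the scatter), which leaves compound 1 alone as the weakest of the four and ties the high number to the 4-bromophenyl group among the aryl groups shown, not to substitution at the 4 position as such. Nothing shown here gives a reason for the size of this step.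

Going by these compounds, whether an amine or a carboxylic acid in the same place would keep the number of compound 4 or lose it stays open, as does the fate of the nitro group at another place on the ring. On these data alone, all four compounds also share one core, so whether the step from bromo to nitro carries over to a different core remains unknown.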